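Compound 4: swapping butylamino for isopropoxy

The compounds below may be only part of what the source reports. "The series", "measured", "known", "first", "only" and "open" are said of these compounds alone.

Measured so far in a physicochemical assay for acid dissociation, are these compounds:
Compound 1 `CCCNC(=N)NC(=N)Nc1ccc(Cl)cc1` gives 10.8
Compound 2 `CCOC(=N)NC(=N)Nc1ccc(Cl)cc1` gives 9.36
Compound 3 `CCCCNC(=N)NC(=N)Nc1ccc(Cl)cc1` gives 10.8

Compound 3 sits at 10.8 and level with compound 1, together the highest of the three numbers. Next comes compound 4 `CC(C)OC(=N)NC(=N)Nc1ccc(Cl)cc1` with isopropoxy in place of butylamino on a carbon with a double bond to nitrogen. For the measured compounds named here, two measured steps bear on this. Ethoxy in place of propylamino gave a number 1.44 log units lower from compound 1 to compound 2 (beyond the scatter) and butylamino in place of ethoxy gave a number 1.44 log units higher from compound 2 to compound 3 (beyond the scatter) in the opposite direction. Methyl in place of hydrogen on the chain gave no change at the digits printed from compound 1 to compound 3 (within the scatter) as a smaller reference. No measurement compares isopropoxy with ethoxy. A large step to a lower number is therefore expected (a number 1.40 log units lower from compound 3 to compound 4 (beyond the scatter)). In this assay compound 4 is estimated at 9.4 with an expected range of 9 to 9.8 around that figure.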

Compound 4, acid dissociation constant: 9.35
Compound 4: the middle estimate sits 0.05 log units above what was measured; the range from low to high includes it.
By their numbers in this assay, from the lowest: compounds 4 and 2 (each within the scatter of the next); then compounds 1 and 3 (each within the scatter of the next).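

Isopropoxy in place of ethoxy gives a number 0.01 log units lower from compound 2 to compound 4 (within the scatter) in this assay, so branching on this oxygen-linked chain leaves the number level. The large gap persists against both amino chains, with a number 1.45 log units lower from compound 3 to compound 4 (beyond the scatter) and a number 1.45 log units lower from compound 1 to compound 4 (beyond the scatter), and at this carbon with a double bond to nitrogen the four compounds fall into an oxygen-linked pair and a nitrogen-linked pair. Nothing available gives a reason for this divide. Still open, as far as these compounds go, is where a sulfur-linked chain or a ring amine such as piperidine would fall at this carbon.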